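The source may report more compounds than this note shows. Statements on the series, on what has been measured and on what is new or still open speak of the compounds shown alone.

Compound 1 `CN1CCN(c2ccc(Nc3ncc4nc(Nc5ccccc5)n([C@H]5CCN(S(C)(=O)=O)C5)c4n3)cc2)CC1` and compound 2 `CN1CCN(c2ccc(Nc3ncc4nc(Nc5ccc(F)cc5)n([C@H]5CCNC5)c4n3)cc2)CC1` share one core and are compared in a functional assay on HCC827 cells (Homo sapiens) for antiproliferative activity, read by MTT assay, with a stated time of 72 h; a lower number here means a stronger inhibitor, a higher number a weaker inhibitor. In this assay compound 1 gives 17 nM, while compound 2 gives 1220 nM, the highest of the two numbers and well beyond the scatter from compound 1. Compound 3 `CN1CCN(c2ccc(Nc3ncc4nc(Nc5ccc(F)cc5)n(CCNS(=O)(=O)C5CC5)c4n3)cc2)CC1` differs from compound 2 in one place: 2-((cyclopropylsulfonyl)amino)ethyl in place of pyrrolidin-3-yl on an aromatic nitrogen. Among the measured compounds shown here, no step between measured compounds covers this change, yet a large move to a lower number is expected, because compound 1 gives 17 nM with a group that also carries a sulfonyl. The estimated step is a 20-fold lower number from compound 2 to compound 3 (1.31 log units; beyond the scatter). Compound 3 is therefore expected to give about 60 nM, within 15 nM to 300 nM.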

Compound 3, half-maximal inhibitory concentration: 50 nM
The estimate for compound 3 lay 1.2-fold (0.08 log units) above the measured number, and the stated range covers the measured number.
By their numbers in this assay, from the lowest: compound 1; then compound 3; then compound 2.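

In this assay, replacing pyrrolidin-3-yl with 2-((cyclopropylsulfonyl)amino)ethyl on the aromatic nitrogen gives a 24-fold lower number from compound 2 to compound 3 (1.39 log units; beyond the scatter), so the group at this position has a large effect on the number. A low number here does not need a ring attached directly to that nitrogen or a defined stereocentre in the group. Nothing measured here explains the change.

This single step alters the ring, chain and sulfonyl together, so it cannot show which part matters. A 2-aminoethyl group, or pyrrolidin-3-yl carrying cyclopropylsulfonyl on its nitrogen, would help separate these parts.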